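A few compounds are considered here, and "the series" means these few. Any claim that something is new, unique, unknown or untested is made for them only; others in the source may bear on it.

Measured compounds:
compound 1 `CCCCCCCCCCCOc1ccccc1CCC(=O)OC[C@H]1OCC=C[C@@H]1OP(=O)(O)OC[C@H](N)C(=O)O`, 7.6%
compound 2 `Cc1ccc(Oc2cccc(COc3ccccc3CCC(=O)OC[C@H]3OCCC[C@H]3OP(=O)(O)OC[C@H](N)C(=O)O)c2)cc1`, "not active" (no number reported)
compound 3 `CCCCCCCCCCCOc1ccccc1CCC(=O)OCc1ccc(OP(=O)(O)OC[C@H](N)C(=O)O)cc1`, "not active" (no number reported)

Within the data shown here, in an assay on HEK293-A cells for agonist activity at putative P2Y purinoceptor 10 (Mus musculus), with a stated time of 1.5 h (a lower number here means a smaller maximal response, a higher number a larger maximal response), compound 1 gives 7.6%; this is the only value reported as a number, since compound 2 is reported as "not active" (no number reported) and compound 3 as "not active" (no number reported) without a number. Compound 4 `CCCCCCCCCCCOc1ccccc1CCC(=O)OC[C@H]1OCC=C[C@H]1OP(=O)(O)OC[C@H](N)C(=O)O` has not been measured in this assay. It differs from compound 1 in one place only: the two compounds have the same atoms and bonds; at least one stereo element is drawn with a configuration in one of them and without one in the other: 1 of 4 stereo elements differ; a stereocentre at a saturated ring carbon is drawn S in compound 1 and R in compound 4. Among the measured compounds shown here, no comparable step between measured compounds is available, so the size of the effect of this change cannot be read from the data. As the atoms and bonds are unchanged, compound 4 is expected to stay close to compound 1, with a step of a number 1.6 percentage points lower from compound 1 to compound 4 (within the scatter) no larger than the usual scatter. Compound 4 is therefore estimated at 6% in this assay, within 0% to 15%.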

Compound 4, largest response reached (Emax), in percent of the reference or control that the assay uses: 12.4%
The estimate for compound 4 lay 6.4 percentage points below the measured number, and the stated range covers the measured number.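

In this assay, among these compounds, the change at this saturated ring carbon gives a number 4.8 percentage points higher from compound 1 to compound 4 (within the scatter), the first comparison at this position, since the earlier compounds offered no step. The drawn configuration here therefore makes no difference that can be told from the scatter, and the maximal response stays small with either S or R. One caution applies to this reading: the fact that one of compounds 1 and 4 is drawn with a defined configuration and the other without, at the place where they differ. The compounds shown leave open whether a phosphonate in place of the phosphate, or a longer chain in place of the one in compound 1, would raise the response.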